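A few compounds are considered here, and "the series" means these few. Any claim that something is new, unique, unknown or untested is made for them only; others in the source may bear on it.

Values in a functional assay on MC-38 cells (Mus musculus) for antiproliferative activity, read by CCK-8 assay, with a stated time of 48 h; on this read-out lower numbers stand for stronger inhibition and higher numbers for weaker inhibition:
Compound 1 `COc1ccc(/C=C\c2cc(OC)c(OC)c(OC)c2)cc1OCc1ccc(CN2CCCC[C@H]2C(=O)O)cc1`: > 10000 nM, a limit of the assay
Compound 2 `COc1ccc(/C=C\c2cc(OC)c(OC)c(OC)c2)cc1OCc1ccc(CN2CCCCC2C(=O)O)cc1`: 5400 nM
Compound 3 `COc1ccc(/C=C\c2cc(OC)c(OC)c(OC)c2)cc1OCc1ccc(CN2CCCCC2C(=O)NCCNC(=O)OC(C)(C)C)cc1`: 1900 nM

Of the two actual numbers, compound 2 has the higher, 5400 nM. The step to its nearest neighbour is a 2.8-fold lower number from compound 2 to compound 3 (0.45 log units; beyond the scatter).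

Compound 4 `COc1ccc(/C=C\c2cc(OC)c(OC)c(OC)c2)cc1OCc1ccc(CN2CC(C(=O)O)C2)cc1` keeps the shared core and differs from compound 2 as follows: 3-carboxyazetidin-1-yl in place of 2-carboxypiperidin-1-yl on a saturated chain carbon bound to an aromatic carbon. In words, 3-carboxyazetidin-1-yl stands in place of 2-carboxypiperidin-1-yl on a saturated chain carbon bound to an aromatic carbon.

Within the data shown here, no measured step makes this exchange. Among the measured compounds shown here, two steps bear on it only indirectly. The first, an at least 1.8-fold lower number from compound 1 to compound 2 (0.26 log units; that floor lies within the scatter), is only a floor because of the limit of > 10000 nM in this assay, at which 1 of the 3 values shown sits, and it concerns (the fact that one of compounds 1 and 2 is drawn with a defined configuration and the other without, at the place where they differ). The second, a 2.8-fold lower number from compound 2 to compound 3 (0.45 log units; beyond the scatter), replaces hydroxy on a carbonyl carbon and is modest. With only these steps as a guide, no step beyond the scatter is expected in this assay, and no clear direction is expected either. The estimated change is a 1.1-fold higher number from compound 2 to compound 4 (0.05 log units; within the scatter).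

For compound 4 the expected value is 6000 nM, estimated to lie between 2000 nM and 18000 nM.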

Compound 4, half-maximal inhibitory concentration: > 10000 nM
Compound 4 gave a limit, no number; the forecaster's own chance of this, stated with the estimate: 30%; at least 1.6-fold (0.22 log units) between middle value and limit.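

In this assay compound 4 gives only a limit, > 10000 nM, and no number. The earlier compounds shown here varied only the drawn configuration and the group on the carbonyl carbon, whereas here the ring itself changes, and putting 3-carboxyazetidin-1-yl in place of 2-carboxypiperidin-1-yl on this saturated chain carbon gives an at least 1.8-fold higher number from compound 2 to compound 4 (0.26 log units; that floor lies within the scatter), so the smaller ring with its carboxylic acid brings no gain in this assay. The step linking compound 1 and compound 4 cannot be read, and the true size of the other step stays unknown, because these values are limits: the limit of > 10000 nM in this assay, at which 2 of the 4 values shown sit.

On these data alone, it remains open how a 2-carboxypyrrolidin-1-yl group would behave at this place. Also open, as far as these compounds go, is whether the (2-((tert-butoxycarbonyl)amino)ethyl)amino group on the carbonyl carbon would lower the number for the 3-carboxyazetidin-1-yl series as it does in a 2.8-fold lower number from compound 2 to compound 3 (0.45 log units; beyond the scatter).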